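A few compounds are considered here, and "the series" means these few. Any claim that something is new, unique, unknown or untested is made for them only; others in the source may bear on it.

Compound 3, with the structure `O=[N+]([O-])c1cc(-c2cc(-c3ccccn3)no2)cc(O)c1O`, gives the lowest of the three numbers recorded in a functional assay on the whole organism (liver, strain NMRI) for inhibition, with Mus musculus as the target, with a stated time of 3 h, at a dose of 3 mg/kg by the oral route; on this read-out lower numbers stand for less inhibition and higher numbers for more inhibition at the one dose given (going by the name of the read-out): compound 3 shows 27.5%. Its nearest neighbour is compound 1, with the structure `Cc1cc(-c2cc(-c3cc(O)c(O)c([N+](=O)[O-])c3)on2)on1`, which in this assay gives 32.4%, and the step of a number 4.9 percentage points lower from compound 1 to compound 3 (within the scatter). The furthest is compound 2, with the structure `O=[N+]([O-])c1cc(-c2cc(-c3cccnc3)no2)cc(O)c1O`, which in this assay gives 33.6%, and the step of a number 6.1 percentage points lower from compound 2 to compound 3 (within the scatter). The third measured step, a number 1.2 percentage points higher from compound 1 to compound 2 (within the scatter), also stays inside the scatter, so all three measured compounds sit at one level in this assay.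

Compound 4, with the structure `O=[N+]([O-])c1cc(-c2cc(-c3cnccn3)no2)cc(O)c1O`, has not yet been measured. The change from compound 3 is pyrazin-2-yl in place of pyridin-2-yl on an aromatic carbon. Every measured step concerns an exchange of the aromatic group at this same place on the shared core, and each of them, a number 6.1 percentage points lower from compound 2 to compound 3 (within the scatter), a number 1.2 percentage points higher from compound 1 to compound 2 (within the scatter) and a number 4.9 percentage points lower from compound 1 to compound 3 (within the scatter), lies within the scatter. Within the data shown here, nothing among the measured compounds points to a movement beyond the scatter for another exchange at this place. Compound 4 is therefore expected to give about 30% in this assay, between 18% and 42%, which means an expected step of a number 2.5 percentage points higher from compound 3 to compound 4 (within the scatter).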

Compound 4, a percentage reported as inhibition, in the whole organism at one dose (the size of the read-out at that dose, not a potency): 44.7%
The estimate for compound 4 lay 14.7 percentage points below the measured number; the measured number lies above the stated range.
By their numbers in this assay, from the lowest: compounds 3, 1 and 2 (each within the scatter of the next); then compound 4.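

In this assay, among these compounds, this place, on an aromatic carbon next to the ring nitrogen, proves sensitive to which aromatic group it carries: pyrazin-2-yl in place of pyridin-2-yl gives a number 17.2 percentage points higher from compound 3 to compound 4 (beyond the scatter), the first step to go beyond the scatter. Among the compounds shown here, the exchanges for pyridin-3-yl and 3-methyl-1,2-oxazol-5-yl agree with it, giving a number 11.1 percentage points higher from compound 2 to compound 4 (beyond the scatter) and a number 12.3 percentage points higher from compound 1 to compound 4 (beyond the scatter), so compound 4 stands apart from the single level shared by compound 1, compound 2 and compound 3. The exchange from compound 3 keeps the six-membered aromatic ring and its 6 heavy atoms and moves from 1 hetero atom to 2, but nothing at hand explains why this raises the number.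

The compounds shown leave open whether the higher number belongs to pyrazin-2-yl alone or would also come with pyrimidin-2-yl or pyridazin-3-yl, and whether an amine or a methoxy group on the pyrazin-2-yl group would keep it. With one dose and one stated time, they also leave open whether the step reflects potency or the duration of the effect.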